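Dropping a Methoxy Group from a Weak Kinase Inhibitor

This account rests on a few compounds, and the source may have more. Where it says the series, first, only, none or still open, it means among the compounds named here.

Measured compounds:
compound 1, `O=C1OC(c2cccc(Br)c2)=N/C1=C\c1ccncc1`: 0%
compound 2, `COc1ccc(C2=N/C(=C\c3cccnc3)C(=O)O2)cc1Br`: 32%

Both compounds were tested in an assay on isolated protein for inhibition of Death-associated protein kinase 3 (Homo sapiens), tested at 10 uM; a higher number here means a stronger effect of the compound at the concentration tested, a lower number a weaker effect. Compound 1 gives 0% there, while compound 2 gives 32%. Of these two numbers, compound 2 has the higher one, and its gap to compound 1 lies beyond the scatter of repeated measurements, so compound 2 is the stronger of the two on this evidence.

Compound 3, `O=C1OC(c2cccc(Br)c2)=N/C1=C\c1cccnc1`, has not yet been measured in this assay. Relative to compound 2 it changes in one place: hydrogen in place of methoxy on an aromatic carbon. The methoxy group is simply removed, with hydrogen taking its place, and nothing else in the shared core is touched.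

Among the compounds with values here, no pair of measured compounds differs in only this group, so the size of the step cannot be read directly from the data. Within the data shown here, since the only compound without a methoxy group, compound 1, gives 0%, a drop for compound 3 is expected rather than a gain, plausibly somewhat beyond the scatter. Compound 3 is therefore estimated to give 12% in this assay, in a range from 0% to 30%. This estimate means an expected step of a number 20 percentage points lower from compound 2 to compound 3 (beyond the scatter).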

Compound 3, a percentage reported as inhibition, at one concentration (the size of the read-out at that concentration, not a potency): 100%
Compound 3: middle estimate off by 88 percentage points, on the low side; measured number outside the range, above it.
By their numbers in this assay, from the lowest: compound 1; then compound 2; then compound 3.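

In this assay, taking away the methoxy group ortho to a bromo group gives a number 68 percentage points higher from compound 2 to compound 3 (beyond the scatter) and so turns a partial read-out into a far stronger one: at this position, hydrogen serves much better than methoxy, at least with pyridin-3-yl in the molecule. The same compound also provides a single-place comparison for the pyridine, since pyridin-3-yl in place of pyridin-4-yl gives a number 100 percentage points higher from compound 1 to compound 3 (beyond the scatter) with everything else held the same. Two separate one-place changes therefore lead to compound 3 with large steps, which shows that the read-out is sensitive to both places, though each step rests on a single pair of compounds.

The compounds shown leave open how other groups at the methoxy position would behave, such as fluoro, a hydroxyl or a longer ethoxy chain, and whether methoxy would have the same effect alongside pyridin-4-yl. Nothing available here accounts for the size of either step, and these single-concentration read-outs give no potency.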